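Pyridyl isomer swap on the shared core: compound 4

This account rests on a few compounds, and the source may have more. Where it says the series, first, only, none or still open, it means among the compounds named here.

Measured in an assay for binding affinity to metabotropic glutamate receptor 5 (Rattus norvegicus); on this read-out higher numbers stand for weaker inhibition and lower numbers for stronger inhibition:
compound 1 `Nc1ccccc1-c1cc(F)cc(-n2nnc(-c3ccccn3)n2)c1` gives 7 nM
compound 2 `Fc1cc(-c2ccccn2)cc(-n2nnc(-c3ccccn3)n2)c1` gives 95 nM
compound 3 `Cc1cnccc1-c1cc(F)cc(-n2nnc(-c3ccccn3)n2)c1` gives 33 nM
compound 4 `Cc1ccc(-c2cc(F)cc(-n3nnc(-c4ccccn4)n3)c2)cn1` has not yet been measured.

Compound 2 stands at the highest number of the three in this assay, with compound 3 nearest and compound 1 furthest away. The step to compound 4 is 6-methylpyridin-3-yl in place of pyridin-2-yl on an aromatic carbon; the fluoro group and the rest of the shared core are left unchanged.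

Two measured steps start from compound 2 and bear on this change. The move to a different aryl group carrying an amino group gave a 14-fold higher number from compound 1 to compound 2 (1.13 log units; beyond the scatter) read in reverse, a large drop. The move to another methyl-bearing pyridyl isomer gave a 2.9-fold lower number from compound 2 to compound 3 (0.46 log units; beyond the scatter), a modest drop. Compound 4 again carries a methylpyridyl group attached through a ring carbon, so the step from compound 2 to compound 3 is the closer guide, and the expected result is a modest lowering of the number, a 2.4-fold lower number from compound 2 to compound 4 (0.38 log units; beyond the scatter), with the large step seen for compound 1 treated as an upper bound rather than the expectation.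

Compound 4 is therefore estimated at 40 nM in this assay, within a range of 15 nM to 120 nM.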

Compound 4, inhibition constant: 36 nM
Compound 4: middle estimate off by 1.1-fold (0.05 log units), on the high side; the range from low to high includes it.
By their numbers in this assay, from the lowest: compound 1; then compounds 3 and 4 (each within the scatter of the next); then compound 2.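

Working notes on this position: in this assay, 6-methylpyridin-3-yl on this aromatic carbon gives a 2.6-fold lower number from compound 2 to compound 4 (0.42 log units; beyond the scatter) against pyridin-2-yl, so a second methylpyridyl group also lies below compound 2 in number. The two methylpyridyl groups are not separated here, since a 1.1-fold higher number from compound 3 to compound 4 (0.04 log units; within the scatter) is within the scatter, and the arrangement of methyl and ring nitrogen in these two isomers therefore shows no readable effect on this read-out. Neither group closes the gap to the 2-aminophenyl compound, as a 5.1-fold higher number from compound 1 to compound 4 (0.71 log units; beyond the scatter) stays beyond the scatter, so compound 1 remains alone at the low end of the series.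

The change from compound 2 to compound 4 alters both the ring attachment and the methyl together, and a pyridin-3-yl without the methyl or a plain phenyl at this position would be needed to separate them and to show how much of the low number of compound 1 goes with its amine. No supporting data are at hand to explain this result.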